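Adding a Second Methyl Group to Compound 2

The source may report more compounds than this note shows. Statements on the series, on what has been measured and on what is new or still open speak of the compounds shown alone.

In a functional assay on HCT-15 cells (Homo sapiens) for cytotoxicity (a lower number here means a stronger inhibitor, a higher number a weaker inhibitor), compound 1 `Oc1nc(-c2ccccc2)cc2ccccc12` gives 5890 nM, while compound 2 `Cc1ccc(-c2cc3ccccc3c(O)n2)cc1` gives 42700 nM, the higher of the two numbers and so the weaker inhibitor. Compound 3 `Cc1ccc(-c2cc3cc(C)ccc3c(O)n2)cc1` differs from compound 2 by one small change: methyl in place of hydrogen on an aromatic carbon. This is methyl in place of hydrogen on an aromatic carbon, on a six-membered aromatic ring of carbon only that is part of a fused or bridged system of two rings. Going by the values given here, only one measured step bears on it: the same kind of swap, made elsewhere in the molecule, gave a 7.2-fold higher number from compound 1 to compound 2 (0.86 log units; beyond the scatter), which lies beyond the scatter. One step at another place is a thin guide, so only a small rise is expected, and no real change would be no surprise. The expected step is a 1.2-fold higher number from compound 2 to compound 3 (0.07 log units; within the scatter). For compound 3 the estimated value is 50000 nM, with an expected range of 15000 nM to 150000 nM.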

Compound 3, half-maximal inhibitory concentration: 35500 nM
Estimate against measurement, compound 3: 1.4-fold (0.15 log units) above; low and high end bracket the measured number.
By their numbers in this assay, from the lowest: compound 1; then compounds 3 and 2 (each within the scatter of the next).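

In this assay, placing a methyl group on this six-membered aromatic ring of carbon only gave a 1.2-fold lower number from compound 2 to compound 3 (0.08 log units; within the scatter), a step within the scatter, so the measurement shows no real change at this position. This differs from the same swap made elsewhere in the molecule, which gave a 7.2-fold higher number from compound 1 to compound 2 (0.86 log units; beyond the scatter), a step beyond the scatter; the effect of a methyl group therefore depends on where it sits in this pair of steps. No supporting data are available to explain why the two steps differ.

From the compounds shown here alone, whether this position would also show no real change with a different group, such as an amine, a carboxylic acid or a longer chain, remains open. One methyl step at one position also says little about the other carbons of this ring.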